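A few compounds are considered here, and "the series" means these few. Any claim that something is new, unique, unknown or untested is made for them only; others in the source may bear on it.

Working notes on the cyanoguanidine series. In an in vitro functional assay on Sf9 cells for antagonist activity at histamine H2 receptor (Homo sapiens) (on this read-out higher numbers stand for higher potency (the scale is a negative logarithm) and lower numbers for lower potency), compound 1 `N#C/N=C(/NCCCCc1c[nH]cn1)NCCCc1ccccn1` gives 5.48. Compound 2 `N#C/N=C(\N)NCCCCc1c[nH]cn1` reaches only the limit of the assay, < 5. As far as these compounds go, compound 3 `CCN/C(=N\C#N)NCCCCc1c[nH]cn1` likewise stops at a limit, < 5; where it stands beneath that limit is unknown, as two of the three values sit there (the limit of < 5 in this assay, at which 2 of the 3 values shown sit). The step of a number at least 0.48 log units lower from compound 1 to compound 3 (beyond the scatter) is the only one readable; a step that the two limits leave unreadable from compound 2 to compound 3 is not. Compound 4 `CC(C)CN/C(=N\C#N)NCCCCc1c[nH]cn1` differs from compound 3 by isopropyl in place of methyl on a saturated chain carbon bound to an amine nitrogen. Neither measured step addresses lengthening a small alkyl on that nitrogen, so compound 3 offers a limit and no direction. Compound 4 is therefore expected to give about 4.7 in this assay, between 4 and 5.4, a step that the limit leaves unreadable from compound 3 to compound 4 that is estimated to stay within the scatter.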

Compound 4, negative logarithm of the antagonist equilibrium constant: < 5
Compound 4: no number, only a limit (the forecaster's own chance of this, stated with the estimate: 65%); the middle value does not contradict the limit.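

Compound 4 also ends at a limit of the assay rather than a number, so isobutyl on the amine nitrogen joins hydrogen and ethyl at that limit: the limit of < 5 in this assay, at which 3 of the 4 values shown sit.

With isopropyl in place of 2-(pyridin-2-yl)ethyl on a saturated chain carbon bound to an amine nitrogen, this assay gives a number at least 0.48 log units lower from compound 1 to compound 4 (beyond the scatter). The steps to compound 4 from compound 2 and from compound 3 cannot be read.

As far as these compounds go, whether a phenyl ring in place of the pyridin-2-yl ring would keep a value above the limit stays open. So does the position of compound 2, compound 3 and compound 4 beneath that limit.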